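Bromo in place of hydrogen, tried once more in the series

The source may hold more compounds than are shown below. What is called first, only, known or untested is meant among the compounds shown, and "the series" means these compounds.

Compound 1 `C=C1C[C@]23C[C@@]1(O)CC[C@H]2c1cc(Br)c(O)c(C)c1[C@@H]3Cn1cc(-c2ccc(F)cc2)nn1`: in a functional assay on MCF7 cells (Homo sapiens) for cytotoxicity, read by MTT assay, with a stated time of 4 days (on this read-out lower numbers stand for stronger inhibition and higher numbers for weaker inhibition), compound 1 gives 19200 nM.
Compound 2 `C=C1C[C@]23C[C@@]1(O)CC[C@H]2c1ccc(O)c(C)c1[C@@H]3Cn1cc(-c2ccc(F)cc2)nn1`: compound 2 reaches only a limit of the assay, > 20000 nM.
Compound 3 `C=C1C[C@]23C[C@@]1(O)CC[C@H]2c1ccc(O)c(C)c1[C@@H]3Cn1cc(-c2ccc(C)cc2)nn1`: compound 3 likewise reaches only a limit, > 20000 nM.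

Two changes connect the measured compounds. From compound 2 to compound 1 the change is bromo in place of hydrogen on an aromatic carbon, and it gives an at least 1.0-fold lower number from compound 2 to compound 1 (0.01 log units; that floor lies within the scatter); the step can only be read as a floor because of the limit of > 20000 nM in this assay, at which 2 of the 3 values shown sit. From compound 2 to compound 3 the change is methyl in place of fluoro on an aromatic carbon, and it gives a step that the two limits leave unreadable from compound 2 to compound 3.

Compound 4 `C=C1C[C@]23C[C@@]1(O)CC[C@H]2c1cc(Br)c(O)c(C)c1[C@@H]3Cn1cc(-c2ccc(C)cc2)nn1` is not yet measured. It differs from compound 3 by bromo in place of hydrogen on an aromatic carbon, the same change as that from compound 2 to compound 1, with the same surroundings. The expectation for compound 4 therefore rests on compound 1 with its 19200 nM and on the step of an at least 1.0-fold lower number from compound 2 to compound 1 (0.01 log units; that floor lies within the scatter): a small step, an at least 1.1-fold lower number from compound 3 to compound 4 (0.07 log units; that floor lies within the scatter), is expected. For compound 4 a value of about 17000 nM is estimated, between 7000 nM and 40000 nM.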

Compound 4, half-maximal inhibitory concentration: > 20000 nM
Compound 4 gave a limit, no number; the forecaster's own chance of this, stated with the estimate: 45%; at least 1.1-fold (0.07 log units) between middle value and limit.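

In this assay compound 4 gives only a limit, > 20000 nM, so bromo in place of hydrogen, carried from the core of compound 2 to that of compound 3, yields no number here. Going by these compounds alone, the one step with a floor is an at least 1.0-fold higher number from compound 1 to compound 4 (0.01 log units; that floor lies within the scatter), for methyl in place of fluoro with bromo present, and it does not separate the two compounds. This shows that compound 1 gives a number where compound 4 gives a limit, but it does not show whether the bromo change has the same size on both cores, and the remaining steps cannot be read because of the limit: the limit of > 20000 nM in this assay, at which 3 of the 4 values shown sit.

The compounds shown leave open whether an amine or a carboxylic acid in place of bromo, ortho to the hydroxy group, would give values clear of this limit. They also leave open whether a longer chain in place of the methyl or fluoro would give a number comparable with that of compound 1.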